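This account rests on a few compounds, and the source may have more. Where it says the series, first, only, none or still open, it means among the compounds named here.

Compound 1 `NC(=S)N/N=C1/C(=O)N(CN2CCN(c3ccnc4cc(Cl)ccc34)CC2)c2cccc(Cl)c21` and compound 2 `NC(=S)N/N=C1/C(=O)N(CN2CCN(c3ccnc4cc(Cl)ccc34)CC2)c2cccc(Br)c21` share one core; compound 3 `NC(=S)N/N=C1\C(=O)Nc2cc(Cl)ccc21` and compound 4 `NC(=S)N/N=C1\C(=O)Nc2cc(Br)ccc21` share another, and the difference between the two cores is not broken down here. In an ADME assay on 184B5 cells (Homo sapiens) for cytotoxicity, read by sulforhodamine B assay, with a stated time of 48 h (a higher number here means a weaker inhibitor of growth, a lower number a stronger inhibitor of growth), compound 1 gives 20700 nM and compound 2 gives 46400 nM, a step of a 2.2-fold higher number from compound 1 to compound 2 (0.35 log units; beyond the scatter) that rests on (bromo in place of chloro on an aromatic carbon). In this assay compound 3 gives 40800 nM. Compound 4 carries the same kind of change on its own core, (bromo in place of chloro on an aromatic carbon); the surroundings differ in that here the carbon is meta to a fused ring and para to a fused ring, whereas in the pair of compound 1 and compound 2 it is ortho to a fused ring and meta to a fused ring. Within the data shown here, because the only precedent is a 2.2-fold higher number from compound 1 to compound 2 (0.35 log units; beyond the scatter), the step for compound 4 in this assay is expected to be a 1.7-fold higher number from compound 3 to compound 4 (0.23 log units; within the scatter). Compound 4 is accordingly estimated at 70000 nM, with a likely range from 35000 nM to 150000 nM.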

Compound 4, concentration for 50% growth inhibition: 34900 nM
The estimate for compound 4 lay 2.0-fold (0.30 log units) above the measured number, and the stated range ends above it.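

In this assay, bromo in place of chloro on the core of compound 3 gives a 1.2-fold lower number from compound 3 to compound 4 (0.07 log units; within the scatter), so this pair shows no separation between the two halogens. Set beside the step on the core of compound 1, the result gives no ground for calling the change dependent on the core: the same change on two cores in this assay, a 2.2-fold higher number (0.35 log units; beyond the scatter) from compound 1 to compound 2 and a 1.2-fold lower number (0.07 log units; within the scatter) from compound 3 to compound 4, 2.6-fold (0.42 log units) apart, within the scatter of two such steps

Among these compounds, this does not show that the change behaves alike on both cores: only two pairs stand here, the halogen sits in different surroundings on each, and only the step on the core of compound 1 lies beyond the scatter.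

Open, on these data alone, is whether fluoro, methoxy, an amine or a carboxylic acid at the same aromatic carbon would move the number on either core.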